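Swapping a difluorophenyl for phenyl on a ketone

The source may report more compounds than this note shows. Statements on the series, on what has been measured and on what is new or still open speak of the compounds shown alone.

Measured compounds:
- compound 1 `O=C1NC(=O)/C(=C/c2ccc(C(=O)NC[C@@H]3C[C@@H](OCc4ccccc4-c4ccccc4)CN3C(=O)c3ccc(C(=O)c4ccccc4)cc3)cc2)S1`: 5500 nM
- compound 2 `O=C1NC(=O)/C(=C/c2ccc(C(=O)NC[C@@H]3C[C@@H](OCc4ccccc4-c4ccccc4)CN3C(=O)c3ccccc3C(=O)c3ccc(F)cc3F)cc2)S1`: 230 nM

Both compounds were tested in a functional assay on THP-1 cells (Homo sapiens) for inhibition; on this read-out lower numbers stand for stronger inhibition and higher numbers for weaker inhibition. Compound 2 has the lowest number of the two, and its nearest neighbour, compound 1, lies well beyond the scatter at the weaker end. Compounds 1 and 2 differ in more than one place, so no single change can be read from that pair; the two values simply show that compound 2 is the stronger inhibitor.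

Compound 3 `O=C1NC(=O)/C(=C/c2ccc(C(=O)NC[C@@H]3C[C@@H](OCc4ccccc4-c4ccccc4)CN3C(=O)c3ccccc3C(=O)c3ccccc3)cc2)S1` has not yet been tested. It differs from compound 2 in one place: phenyl in place of 2,4-difluorophenyl on a carbonyl carbon. Two fluorine atoms are removed from the ring that sits on the ketone, and nothing else changes.

Nothing in the measured pair speaks to this particular change, so the expectation rests on compound 2 alone and on the general experience that such a small change usually moves a value only modestly. The expected step from compound 2 to compound 3 is a 2.0-fold higher number from compound 2 to compound 3 (0.29 log units; within the scatter), toward slightly weaker inhibition in this assay. Compound 3 is estimated at 450 nM, with a range from 150 nM to 1400 nM.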

Compound 3, half-maximal inhibitory concentration: 670 nM
Beside the measured number, compound 3's estimate is 1.5-fold (0.17 log units) below it; the measured number falls inside the stated range.
By their numbers in this assay, from the lowest: compound 2; then compound 3; then compound 1.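

In this assay, removing the two fluorine atoms from the ring on the ketone gives a 2.9-fold higher number from compound 2 to compound 3 (0.46 log units; beyond the scatter), a modest step but one beyond the usual scatter. Among these compounds, this is the first comparison that isolates a single change, as compounds 1 and 2 differ in more than one place, and it shows that the ring on this carbonyl carbon affects inhibition in these cells, with 2,4-difluorophenyl giving the lower number and phenyl the higher. No available evidence accounts for the size or direction of this step, so the numbers record the effect without explaining it.

It remains open whether both fluorine atoms are needed for the stronger inhibition, as a ring carrying only one fluorine atom is not among the compounds shown. It is also unknown how a chlorine atom, a methyl group or a methoxy group on this ring would compare, or whether the same step would appear with a different group elsewhere on the shared core.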